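The source may report more compounds than this note shows. Statements on the series, on what has been measured and on what is new or still open speak of the compounds shown alone.

Values in an ADME assay on BE(2)-C cells (Homo sapiens) for cytotoxicity, read by MTT assay, with a stated time of 20 h; on this read-out higher numbers stand for lower toxicity in this test and lower numbers for higher toxicity in this test:
- compound 1 (`CN(Cc1ccccc1)C(=O)C1CCN(C(=O)c2cc3ccccc3n2Cc2ccc([N+](=O)[O-])cc2)CC1`) gives > 100000 nM, a limit of the assay
- compound 2 (`CN(Cc1ccccc1)C(=O)C1CCN(C(=O)c2cc3ccccc3n2Cc2ccc(C#N)cc2)CC1`) gives > 100000 nM, a limit of the assay
- compound 3 (`CC(C)Cn1c(C(=O)N2CCC(C(=O)N(C)Cc3ccccc3)CC2)cc2ccccc21`) gives 58200 nM

Going by the values given here, compound 3 holds the only actual number, since the other two results are limits. The ceiling in play is the limit of > 100000 nM in this assay, at which 2 of the 3 values shown sit.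

Compound 4 (`CN(Cc1ccccc1)C(=O)C1CCN(C(=O)c2cc3ccccc3n2Cc2ccc(C(F)(F)F)cc2)CC1`) differs from compound 3 by 4-(trifluoromethyl)phenyl in place of isopropyl on a saturated chain carbon bound to an aromatic nitrogen.

Among the compounds with values here, two measured steps bear on this change, and both run the opposite way, from a substituted phenyl to isopropyl: an at least 1.7-fold lower number from compound 1 to compound 3 (0.23 log units; that floor lies within the scatter) and an at least 1.7-fold lower number from compound 2 to compound 3 (0.23 log units; that floor lies within the scatter). Both floors lie within the scatter, so they give only weak guidance. The swap among the phenyl substituents is no help, being a step that the two limits leave unreadable from compound 1 to compound 2.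

A higher number in this assay is therefore expected, though not clearly beyond the scatter. The expected step is a 1.7-fold higher number from compound 3 to compound 4 (0.24 log units; within the scatter). A report as a limit is quite possible. Compound 4 is estimated at 100000 nM, with an expected range of 45000 nM to 170000 nM.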

Compound 4, half-maximal cytotoxic concentration: 90300 nM
Compound 4: middle estimate off by 1.1-fold (0.04 log units), on the high side; low and high end bracket the measured number.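

In this assay, going by these compounds alone, compound 4 holds the only actual number among the compounds with a substituted phenyl at this position. Replacing isopropyl gives a 1.6-fold higher number from compound 3 to compound 4 (0.19 log units; within the scatter) and so leaves isopropyl and 4-(trifluoromethyl)phenyl unseparated on a saturated chain carbon bound to an aromatic nitrogen, even with the added aromatic ring. On the aromatic carbon, trifluoromethyl gives an at least 1.1-fold lower number from compound 2 to compound 4 (0.04 log units; that floor lies within the scatter) in place of nitrile and an at least 1.1-fold lower number from compound 1 to compound 4 (0.04 log units; that floor lies within the scatter) in place of nitro, and these remain floors inside the scatter because the nitrile and nitro compounds are reported only as limits: the limit of > 100000 nM in this assay, at which 2 of the 4 values shown sit.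

Still open, going by these compounds, is whether an amine or a carboxylic acid on the phenyl ring would move the number beyond the scatter. A longer chain in place of isobutyl is equally untested by the compounds shown.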